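A few compounds are considered here, and "the series" means these few. Any claim that something is new, unique, unknown or untested is made for them only; others in the source may bear on it.

The two measured compounds share a core built around the same aryl ether linked to an amide. Compound 1 `O=C(Nc1ccc(Oc2ccncc2-c2cccnc2)c(F)c1)c1nn(-c2ccc(F)cc2)c(=O)c2ccccc12` carries one kind of heterocyclic amide and a 4-fluorophenyl on its ring nitrogen; in a functional assay on MKN-45 cells (Homo sapiens) for cytotoxicity, read by MTT assay, with a stated time of 72 h (a higher number here means a weaker inhibitor, a lower number a stronger inhibitor), compound 1 gives 320 nM. Compound 2 `O=C(Nc1ccc(Oc2ccncc2-c2cccnc2)c(F)c1)c1ccnn(-c2ccc(Cl)cc2)c1=O` has a different amide ring and a 4-chlorophenyl; in this assay compound 2 gives 4230 nM. Compound 2 therefore stands at the higher of the two numbers, and its gap to compound 1 lies beyond the scatter, but the two compounds differ in more than one place, so the gap cannot be assigned to either change alone.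

Compound 3 `O=C(Nc1ccc(Oc2ccncc2-c2cccnc2)c(F)c1)c1ccnn(-c2ccc(F)cc2)c1=O` differs from compound 2 only by fluoro in place of chloro on an aromatic carbon. Nothing measured here isolates this swap, so the step from compound 2 to compound 3 is expected to be small, a 1.1-fold lower number from compound 2 to compound 3 (0.02 log units; within the scatter), within the scatter. Compound 3 is accordingly estimated at 4000 nM, with a range from 1500 nM to 12000 nM.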

Compound 3, half-maximal inhibitory concentration: 3120 nM
The estimate for compound 3 lay 1.3-fold (0.11 log units) above the measured number, and the stated range covers the measured number.
By their numbers in this assay, from the lowest: compound 1; then compounds 3 and 2 (each within the scatter of the next).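

In this assay, among the compounds shown here, this pair gives the first clean reading at this position: putting fluoro in place of chloro on the aromatic ring gives a 1.4-fold lower number from compound 2 to compound 3 (0.13 log units; within the scatter), so these two halogens are not told apart here. Compound 3 also carries the same 4-fluorophenyl as compound 1, yet compound 3 gives 3120 nM and compound 1 gives 320 nM, so the halogen swap does not reproduce the gap seen earlier, and the amide ring is the remaining difference between those two compounds. No measurement here explains why the swap changes so little.

Going by these compounds, whether an amine or a carboxylic acid at this same position would shift the number beyond the scatter remains open. So does whether chloro in place of fluoro would behave the same way on compound 1.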